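From thiophen-2-yl to furan-2-yl on compound 1

The source may hold more compounds than are shown below. What is called first, only, known or untested is meant among the compounds shown, and "the series" means these compounds.

Compound 1 `COc1ccc(S(=O)(=O)N(CCC#N)Cc2cccs2)cc1` has no exact reading in an ADME assay on MDCK cells (Canis lupus familiaris) for cytotoxicity, read by MTT assay, with a stated time of 24 h (on this read-out lower numbers stand for higher toxicity in this test and higher numbers for lower toxicity in this test), where compound 1 gives only a limit, > 198000 nM. Compound 2 `N#CCCN(Cc1cccs1)S(=O)(=O)c1ccc([N+](=O)[O-])cc1` is also known only as a limit, > 189000 nM. Within the data shown here, the one measured change, nitro in place of methoxy on an aromatic carbon, is a step that the two limits leave unreadable from compound 1 to compound 2, so it offers no size to carry over, and it lies at a different place in the structure. Compound 3 `COc1ccc(S(=O)(=O)N(CCC#N)Cc2ccco2)cc1` changes the other end of compound 1: furan-2-yl in place of thiophen-2-yl on a saturated chain carbon bound to a sulfonamide nitrogen. Among the measured compounds shown here, no measured step covers this swap. The expectation therefore rests on compound 1, with its limit of > 198000 nM, and no step beyond the usual scatter is expected in this assay. The expected result is a step that the limit leaves unreadable from compound 1 to compound 3. Compound 3 is estimated at 205000 nM, within an expected range of 90000 nM to 400000 nM, and may well be reported only as a limit.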

Compound 3, half-maximal cytotoxic concentration: > 208000 nM
Compound 3: no number, only a limit (the forecaster's own chance of this, stated with the estimate: 80%); middle value at least 1.0-fold (0.00 log units) away from the limit.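

Compound 1 and compound 3 each give only a limit, and the step between them, furan-2-yl in place of thiophen-2-yl, cannot be read. The compounds shown leave open at what concentration compound 1, compound 2 or compound 3 would turn toxic in this assay.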